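A few compounds are considered here, and "the series" means these few. Any claim that something is new, unique, unknown or untested is made for them only; others in the source may bear on it.

In an ADME assay on Caco-2 cells (Homo sapiens) for permeability, in the apical to basolateral direction (on this read-out higher numbers stand for higher permeability and lower numbers for lower permeability), compound 1 `Cn1cncc1CN1CC(N(CC2CCN(C(=O)c3ccc(Cl)cc3)CC2)S(=O)(=O)c2ccccn2)Cc2cc(C#N)ccc21` gives 0.5 10^-6 cm/s.
Compound 2 `CCCC(=O)N1CCC(CN(C2Cc3cc(C#N)ccc3N(Cc3cncn3C)C2)S(=O)(=O)c2ccccn2)CC1` gives 0.5 10^-6 cm/s.
Compound 3 `Cn1cncc1CN1CC(N(CC2CCN(C(=O)C(C)(C)C)CC2)S(=O)(=O)c2ccccn2)Cc2cc(C#N)ccc21` gives 0.5 10^-6 cm/s.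

On these numbers compound 2 stands level with compounds 1 and 3. All three share one core and differ only in the group on a carbonyl carbon, and the steps of no change at the digits printed from compound 1 to compound 2 (within the scatter), no change at the digits printed from compound 1 to compound 3 (within the scatter) and no change at the digits printed from compound 2 to compound 3 (within the scatter) show that exchanging 4-chlorophenyl, propyl and tert-butyl there leaves the read-out where it was. Compound 4 `Cn1cncc1CN1CC(N(CC2CCN(C(=O)c3cccs3)CC2)S(=O)(=O)c2ccccn2)Cc2cc(C#N)ccc21` changes the same place: thiophen-2-yl in place of propyl on a carbonyl carbon. Since every earlier swap at this carbonyl carbon stayed within the scatter, no step beyond the scatter is expected in this assay. The expected step is no change at the digits printed from compound 2 to compound 4 (within the scatter). Compound 4 is therefore estimated at 0.5 10^-6 cm/s, within 0.25 10^-6 cm/s to 1 10^-6 cm/s.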

Compound 4, apparent permeability: 0.5 10^-6 cm/s
Compound 4: the middle estimate sits on the measured number at the digits printed, within the range that was stated.
By their numbers in this assay, from the lowest: compounds 1, 2, 3 and 4 (each within the scatter of the next).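

In this assay, thiophen-2-yl puts an aromatic ring with a hetero atom on this carbonyl carbon, and the read-out gives no change at the digits printed from compound 2 to compound 4 (within the scatter) and no change at the digits printed from compound 3 to compound 4 (within the scatter) and also no change at the digits printed from compound 1 to compound 4 (within the scatter) at this position. The flat read-out here now covers a five-membered aromatic ring with sulfur, alongside propyl, tert-butyl and 4-chlorophenyl. Nothing available explains why the read-out stays level.

On these data alone, whether an amine or a carboxylic acid on this carbonyl carbon would shift the read-out remains open. So does whether a change elsewhere on the shared core would move it.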